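A bulkier aryl group on the weakest of three analogues

The source may report more compounds than this note shows. Statements on the series, on what has been measured and on what is new or still open speak of the compounds shown alone.

Three analogues sharing one core were compared in a functional assay on HepG2 cells (Homo sapiens) for cytotoxicity, read by MTT assay, with a stated time of 72 h; on this read-out higher numbers stand for weaker inhibition and lower numbers for stronger inhibition. Compound 1 `Cc1cc(=O)n(-c2cccc(F)c2)nc1C(=O)Nc1ccc(Oc2ncnc3[nH]ccc23)cc1` gave 3180 nM. Compound 2 `Cc1ccc(-n2nc(C(=O)Nc3ccc(Oc4ncnc5[nH]ccc45)cc3)c(C)cc2=O)cc1` gave 7460 nM, and compound 3 `Cc1cc(=O)n(-c2cccc(F)c2)nc1C(=O)Nc1ccc(Oc2ncnc3[nH]ccc23)c(F)c1` gave 23100 nM. Compound 3 therefore stands highest of the three numbers: the steps of a 2.3-fold higher number from compound 1 to compound 2 (0.37 log units; beyond the scatter) and a 7.3-fold higher number from compound 1 to compound 3 (0.86 log units; beyond the scatter) are both beyond the scatter, and compound 3 also sits above compound 2.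

Compound 4 `Cc1cc(=O)n(-c2ccccc2OC(F)(F)F)nc1C(=O)Nc1ccc(Oc2ncnc3[nH]ccc23)c(F)c1` differs from compound 3 by 2-(trifluoromethoxy)phenyl in place of 3-fluorophenyl on an aromatic nitrogen. Among the compounds with values here, the one measured step that bears on this position is a 2.3-fold higher number from compound 1 to compound 2 (0.37 log units; beyond the scatter), where another aryl group replaced the same 3-fluorophenyl on the aromatic nitrogen and produced a modest rise. Within the data shown here, the present exchange is of a different kind and is larger, so no close precedent exists. Compound 4 is therefore expected to show a small step, upward if anything, a 1.5-fold higher number from compound 3 to compound 4 (0.18 log units; within the scatter). Compound 4 is estimated at 35000 nM in this assay, with a range from 12000 nM to 100000 nM.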

Compound 4, half-maximal inhibitory concentration: > 60000 nM
Compound 4: no number, only a limit; the forecaster's own chance of this, stated with the estimate: 15%; at least 1.7-fold (0.23 log units) between middle value and limit.
By their numbers in this assay, from the lowest: compound 1; then compound 2; then compound 3. At a limit, above all of these: compound 4.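

In this assay compound 4 gives only a limit, > 60000 nM, not a number. The 2-(trifluoromethoxy)phenyl exchange yields an at least 2.5-fold higher number from compound 3 to compound 4 (0.41 log units; beyond the scatter), showing that the aryl group on this aromatic nitrogen still moves the read-out beyond the scatter in the fluoro-bearing series, whereas the earlier aryl change, a 2.3-fold higher number from compound 1 to compound 2 (0.37 log units; beyond the scatter), came from the series without that fluoro. How far this step truly runs cannot be read from the result: the limit of > 60000 nM in this assay, at which 1 of the 4 values shown sits.

On these data alone, it remains open whether the same exchange would move compound 1 as far, and whether the trifluoromethoxy group elsewhere on the phenyl ring would give a measurable number. Also open, as far as these compounds go, is whether an amine or a carboxylic acid on that ring would bring the read-out back down.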